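Compound 4: Expecting No Readable Cytotoxicity Step

The source may report more compounds than this note shows. Statements on the series, on what has been measured and on what is new or still open speak of the compounds shown alone.

In an ADME assay on HEK-293T cells (Homo sapiens) for cytotoxicity, read by CCK-8 assay, with a stated time of 48 h (a lower number here means a stronger inhibitor, a higher number a weaker inhibitor), compound 1 (`COc1ccc(NC(=O)NCCNS(=O)(=O)c2ccc(-c3ccccc3OCc3ccccc3)s2)cc1`) gives > 50000 nM, a limit and not a number. Compound 2 (`O=C(NCCNS(=O)(=O)c1ccc(-c2ccccc2OCc2cccc(O)c2)s1)Nc1cc(Cl)cc(Cl)c1`) gives > 20000 nM, also a limit. Compound 3 (`Cc1cc(C)cc(NC(=O)NCCNS(=O)(=O)c2ccc(-c3ccccc3OCc3cccc(O)c3)s2)c1`) gives > 20000 nM, again only a limit. Compound 4 (`COc1ccc(NC(=O)NCCNS(=O)(=O)c2ccc(-c3ccccc3OCc3cccc(O)c3)s2)cc1`) has not been measured; it carries 4-methoxyphenyl in place of 3,5-dimethylphenyl on an amide-type nitrogen. Within the data shown here, the one measured change on that nitrogen, a step that the two limits leave unreadable from compound 2 to compound 3, has no readable size. No step beyond the scatter is therefore expected, and neither direction is favoured. The expected change, a step that the limit leaves unreadable from compound 3 to compound 4, is an estimate only. For compound 4 the estimated value is 30000 nM, with an expected range of 15000 nM to 70000 nM.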

Compound 4, half-maximal inhibitory concentration: > 20000 nM
Compound 4: only a limit was reported; the forecaster's own chance of this, stated with the estimate: 85%; the middle value lies beyond the limit too.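

Among these compounds, compound 1, compound 2, compound 3 and compound 4 all give only limits in this assay, so no step among them can be read. The compounds shown leave open whether the group on the amide-type nitrogen affects cytotoxicity at all.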